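Replacing one aryl group: what to expect for compound 3

This account rests on a few compounds, and the source may have more. Where it says the series, first, only, none or still open, it means among the compounds named here.

Measured in a functional assay on MCF7 cells (Homo sapiens) for antiproliferative activity, read by MTT assay, with a stated time of 72 h (a lower number here means a stronger inhibitor, a higher number a weaker inhibitor), so far:
- compound 1 `O=C(N/N=C/c1ccc([N+](=O)[O-])cc1)Nc1ccc(Oc2ccnc3[nH]ccc23)c(F)c1` gives 4000 nM
- compound 2 `O=C(N/N=C/c1ccc(F)cc1Cl)Nc1ccc(Oc2ccnc3[nH]ccc23)c(F)c1` gives 7610 nM

Compound 2 lies within the usual scatter of compound 1, so the two cannot be ranked. Compound 3 `O=C(N/N=C/c1ccc(O)cc1)Nc1ccc(Oc2ccnc3[nH]ccc23)c(F)c1` differs from compound 2 in a single group: 4-hydroxyphenyl in place of 2-chloro-4-fluorophenyl on a carbon with a double bond to nitrogen is the whole change. Among the measured compounds shown here, the one measured step at that place is a 1.9-fold higher number from compound 1 to compound 2 (0.28 log units; within the scatter) and it stayed within the scatter, so no step beyond the scatter is expected in this assay and no direction can be foreseen. The estimate means a 1.4-fold lower number from compound 2 to compound 3 (0.14 log units; within the scatter) as the expected step. Compound 3 is expected at 5500 nM with an estimated range of 2000 nM to 15000 nM for now.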

Compound 3, half-maximal inhibitory concentration: "not active" (no number reported)
Compound 3 has no reported number here, so the estimate cannot be set against anything.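

Among the compounds shown here, compound 3 is reported in this assay only as "not active", without a number, so no step from compound 2 to compound 3 can be read. No measurement shown explains this result. The compounds shown leave open how 4-hydroxyphenyl truly compares with 2-chloro-4-fluorophenyl.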